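This account rests on a few compounds, and the source may have more. Where it says the series, first, only, none or still open, it means among the compounds named here.

Measured so far:
compound 1, `O=S(=O)(c1cccc(F)c1)c1cnc2c(F)cccc2c1-c1cccc(Cl)c1`, 0.56 mL/min
compound 2, `O=S(=O)(c1ccc(F)c(F)c1)c1cnc2c(F)cccc2c1-c1ccc(F)cc1`, 0.78 mL/min

In an ADME assay on microsomes from liver (Homo sapiens) for metabolic stability, tested at 2.5 uM (a lower number here means slower removal, a higher number faster removal of the compound), compound 1 gives 0.56 mL/min, and compound 2 gives 0.78 mL/min. Compound 2 holds the higher of the two numbers, but its nearest neighbour is compound 1, whose number is lower by an amount within the scatter of repeated measurements, so the two values cannot be told apart with confidence in this assay.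

Compound 3, `O=S(=O)(c1cccc(F)c1)c1cnc2c(F)cccc2c1-c1ccc(F)cc1`, has not yet been measured. It differs from compound 2 at one point on the sulfonyl-bearing aryl ring, where (hydrogen in place of fluoro on an aromatic carbon).

Among the compounds with values here, no step between measured compounds with this exact change is available, so its size is not known from the data. Given that both measured values sit close together, the step from compound 2 to compound 3 is expected to be small, and no direction beyond the scatter is anticipated: a 1.1-fold lower number from compound 2 to compound 3 (0.05 log units; within the scatter). The number for compound 3 in this assay is accordingly estimated at 0.7 mL/min, with a range from 0.4 mL/min to 1.2 mL/min.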

Compound 3, intrinsic clearance in a liver preparation (reported as CLH), per the amount of preparation that the assay uses: 0.19 mL/min
Compound 3: middle estimate off by 3.7-fold (0.57 log units), on the high side; the whole stated range lies above it.
By their numbers in this assay, from the lowest: compound 3; then compounds 1 and 2 (each within the scatter of the next).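

In this assay the change from 3,4-difluorophenyl to 3-fluorophenyl gives a 4.1-fold lower number from compound 2 to compound 3 (0.61 log units; beyond the scatter) and so shows that this single aromatic carbon, para to a large group, can move the number beyond the scatter. The two earlier compounds, which lie within the scatter of each other and differ in more than one place, could not show this. The other new step, with 4-fluorophenyl in place of 3-chlorophenyl, gives a 2.9-fold lower number from compound 1 to compound 3 (0.47 log units; beyond the scatter) and shows that the aryl group changed there also matters in this read-out. Compound 3 therefore has the lowest number of the three, with its steps to both others beyond the scatter.

On these data alone, it remains open whether hydrogen is unusual at this aromatic carbon or whether another group there, such as a methoxy group or an amine, would give a similarly low number, and whether the step from the fluoro to hydrogen holds when 3-chlorophenyl replaces 4-fluorophenyl. Nothing on hand explains either step.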